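The source may hold more compounds than are shown below. What is called first, only, known or untested is meant among the compounds shown, and "the series" means these compounds.

Compound 2 `C/C(=C\C(=O)Nc1ccccc1OCCCC(=O)O)c1ccc2c(ccn2CC(C)C)c1` is measured in an assay on Prostate gland for inhibition of steroid 5-alpha-reductase (Rattus norvegicus) (a higher number here means a weaker inhibitor, a lower number a stronger inhibitor), where compound 2 gives 160 nM. Among the compounds with values here, of the two numbers known so far, compound 2 has the highest; its nearest neighbour, compound 1 `CCCCCCn1ccc2cc(/C(C)=C/C(=O)Nc3ccccc3OCCCC(=O)O)ccc21`, gives 77 nM. Compound 3 `CC(C)=CCn1ccc2cc(/C(C)=C/C(=O)Nc3ccccc3OCCCC(=O)O)ccc21` has not yet been measured. It differs from compound 2 by 2-methylprop-1-en-1-yl in place of isopropyl on a saturated chain carbon bound to an aromatic nitrogen. Within the data shown here, only one measured step touches this part of the molecule: a 2.1-fold higher number from compound 1 to compound 2 (0.32 log units; beyond the scatter), in which the shorter branched group gave a somewhat weaker inhibitor than the longer straight chain. Given that the only comparable step is a 2.1-fold higher number from compound 1 to compound 2 (0.32 log units; beyond the scatter), and that the new group in compound 3 lies in size between isopropyl and pentyl, a modest move back toward the number of compound 1 is expected rather than no change. The estimate for compound 3 in this assay is therefore 100 nM, with a range from 40 nM to 250 nM, meaning an expected step of a 1.6-fold lower number from compound 2 to compound 3 (0.20 log units; within the scatter).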

Compound 3, half-maximal inhibitory concentration: 120 nM
The estimate for compound 3 lay 1.2-fold (0.08 log units) below the measured number, within the range that was stated.
By their numbers in this assay, from the lowest: compounds 1, 3 and 2 (each within the scatter of the next, the first and the last beyond it).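

In this assay, placing 2-methylprop-1-en-1-yl on the saturated chain carbon bound to an aromatic nitrogen gives a 1.3-fold lower number from compound 2 to compound 3 (0.12 log units; within the scatter) when it replaces isopropyl and a 1.6-fold higher number from compound 1 to compound 3 (0.19 log units; within the scatter) when it replaces pentyl. Compound 3 therefore cannot be told apart from either compound, even though compound 1 and compound 2 differ from each other by more than the scatter. This shows that a chain with a double bond outside aromatic rings can stand at this position without a step beyond the scatter from either saturated chain. No supporting measurement is available to explain these numbers.

The compounds shown carry only hydrocarbon chains here, so it remains open how a chain ending in an amine or a carboxylic acid would behave. A much longer chain, such as decyl, also remains untested in the compounds shown.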